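The compounds below may be only part of what the source reports. "The series", "measured", "known", "first", "only" and "open" are said of these compounds alone.

Measured so far in a functional assay on HepG2 cells (Homo sapiens) for antiproliferative activity, read by MTT assay, with a stated time of 24 h; a lower number here means a stronger inhibitor, a higher number a weaker inhibitor:

Compound 1 `O=[N+]([O-])c1cccc(CSc2nnc(-c3ccc4c(c3)OCCO4)n2-c2ccccc2)c1` gives 49300 nM
Compound 2 `Cc1ccccc1CSc1nnc(-c2ccc3c(c2)OCCO3)n1-c1ccccc1` gives 20500 nM
Compound 3 `Cc1ccc(CSc2nnc(-c3ccc4c(c3)OCCO4)n2-c2ccccc2)cc1` gives 56800 nM

Compound 3 stands at 56800 nM in this small set. The comparison a 1.2-fold higher number from compound 1 to compound 3 (0.06 log units; within the scatter) leaves that pair level, while a 2.8-fold higher number from compound 2 to compound 3 (0.44 log units; beyond the scatter) is a modest step toward a weaker number.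

Compound 4 `Brc1cccc(CSc2nnc(-c3ccc4c(c3)OCCO4)n2-c2ccccc2)c1` carries 3-bromophenyl in place of 4-methylphenyl on a saturated chain carbon bound to a sulfur, a change counted as 3-bromophenyl in place of 4-methylphenyl on a saturated chain carbon bound to a sulfur with the rest of the structure unchanged. Within the data shown here, no compound with 3-bromophenyl has a measured value yet. The closest guide is compound 1 with its 3-nitrophenyl, since the exchange of that group for 4-methylphenyl gave a 1.2-fold higher number from compound 1 to compound 3 (0.06 log units; within the scatter) and so no real change. The two larger steps, a 2.4-fold lower number from compound 1 to compound 2 (0.38 log units; beyond the scatter) and a 2.8-fold higher number from compound 2 to compound 3 (0.44 log units; beyond the scatter), both involve 2-methylphenyl, which compound 4 does not carry.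

A shift beyond the scatter is therefore not expected in this assay, and any drift toward a lower number would be slight. The estimated change is a 1.4-fold lower number from compound 3 to compound 4 (0.13 log units; within the scatter) and no more than that is expected. Compound 4 is estimated at 42000 nM with an expected range of 20000 nM to 85000 nM on repeated measurement.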

Compound 4, half-maximal inhibitory concentration: 5210 nM
The estimate for compound 4 lay 8.1-fold (0.91 log units) above the measured number, outside the stated range (below it).
By their numbers in this assay, from the lowest: compound 4; then compound 2; then compounds 1 and 3 (each within the scatter of the next).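

In this assay, among these compounds, the group on the saturated chain carbon bound to a sulfur proves able to shift the number far more than the earlier compounds showed, with an 11-fold lower number from compound 3 to compound 4 (1.04 log units; beyond the scatter) as a large step, even though the leaving and entering groups match in heavy-atom count and neither carries a hydrogen-bond donor or acceptor. The identity of the ring substituent matters as well, since a 9.5-fold lower number from compound 1 to compound 4 (0.98 log units; beyond the scatter) with bromo in place of nitro on an aromatic carbon, and 3-bromophenyl also improves on the previous lowest number, with a 3.9-fold lower number from compound 2 to compound 4 (0.59 log units; beyond the scatter) as a modest step. Nothing available explains why bromo gives this result.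

The compounds shown leave open whether the low number belongs to bromine itself, which 3-chlorophenyl or 3-iodophenyl on the same chain carbon would test. They also leave open whether bromine keeps this effect in 2-bromophenyl or 4-bromophenyl, and whether a 3-aminophenyl group would fit the same trend.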